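Replacing the Substituted Phenyl on the Amide Nitrogen

The source may report more compounds than this note shows. Statements on the series, on what has been measured and on what is new or still open speak of the compounds shown alone.

Measured compounds:
compound 1 `COC(=O)c1ccc(N(Cc2cnc(C3CCCCC3)cn2)C(=O)[C@H]2CCN2S(=O)(=O)c2c(F)c(F)c(F)c(F)c2F)cc1O`: 1600 nM
compound 2 `CONC(=O)c1ccc(N(Cc2ccc(C3CCCCC3)cn2)C(=O)[C@H]2CCN2S(=O)(=O)c2c(F)c(F)c(F)c(F)c2F)cc1O`: 6700 nM

In a functional assay on MDA-MB-231 cells (Homo sapiens) for antiproliferative activity, with a stated time of 72 h (a higher number here means that more compound is needed for the effect, a lower number that less compound is needed), compound 1 gives 1600 nM. Compound 2, the other measured compound, gives 6700 nM in this assay. For the measured compounds named here, compound 2 therefore stands at the highest of the two numbers, and its distance from compound 1 lies beyond the usual scatter; the two structures differ in more than one place, so the two values show only that compound 2 needs more compound for the effect.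

Compound 3 `O=C([C@H]1CCN1S(=O)(=O)c1c(F)c(F)c(F)c(F)c1F)N(Cc1ccc(C2CCCCC2)cn1)c1ccc2c(=O)[nH]ccc2c1` is not yet measured. Compared with compound 2 the change is a group of 11 heavy atoms (9 carbon, 1 nitrogen, 1 oxygen; one six-membered aromatic ring of carbon only, one six-membered aromatic ring with 1 hetero atom) in place of a group of 12 heavy atoms (8 carbon, 1 nitrogen, 3 oxygen; one six-membered aromatic ring of carbon only), on an amide-type nitrogen. Going by the values given here, no measured pair in this set isolates such a change, so there is no directly comparable step to lean on. The reference point is compound 2 with 6700 nM, which leaves room for the number to move either way. The step from compound 2 to compound 3 is expected to be a moderate decrease, a 1.7-fold lower number from compound 2 to compound 3 (0.22 log units; within the scatter), with wide uncertainty. Compound 3 is estimated at 4000 nM, in a range from 800 nM to 20000 nM.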

Compound 3, half-maximal effective concentration: 1200 nM
Compound 3: middle estimate off by 3.3-fold (0.52 log units), on the high side; the range from low to high includes it.
By their numbers in this assay, from the lowest: compounds 3 and 1 (each within the scatter of the next); then compound 2.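

Compound 3 carries neither the hydroxy nor the methoxycarbamoyl group of the 3-hydroxy-4-(methoxycarbamoyl)phenyl, yet in this assay the exchange on the amide-type nitrogen gives a 5.6-fold lower number from compound 2 to compound 3 (0.75 log units; beyond the scatter) and so moves the number down rather than up. Compound 1 and compound 2 both carry a hydroxy-substituted phenyl here, so they could not show that this place accepts a group with one six-membered aromatic ring of carbon only and one six-membered aromatic ring with 1 hetero atom, which has 1 hydrogen-bond donor and 1 hydrogen-bond acceptor where the group it replaces has 2 and 3. Nothing measured on these compounds gives a reason for the step.

This single pair changes the whole group at once, so it cannot say whether the loss of the hydroxy group, the loss of the methoxycarbamoyl group or the added ring accounts for the lower number. The compounds shown also leave open how an unsubstituted phenyl, or a phenyl carrying an amine or a carboxylic acid, would behave on this nitrogen.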